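The source may hold more compounds than are shown below. What is called first, only, known or untested is meant among the compounds shown, and "the series" means these compounds.

In a functional assay on DU-145 cells (Homo sapiens) for antiproliferative activity, read by MTT assay, with a stated time of 72 h (a lower number here means a stronger inhibitor, a higher number a weaker inhibitor), compound 2, `O=C(COc1ccc(C(=O)/C=C/c2ccccc2Cl)cc1)N[C@H]1CCOC1=O`, gives 3240 nM, the lowest of the two plain numbers that this small set provides. Its nearest measured neighbour is compound 3, `O=C1OCC[C@@H]1NC(=S)SCCOc1ccccc1`, which in this assay gives 63800 nM, a gap that lies well beyond the usual scatter. Compound 1, `Cc1ccc(C(C)C)c(OCCSC(=S)N[C@H]2CCOC2=O)c1`, reaches only a limit of this assay, > 64000 nM, so no number is available for it, and the limit of > 64000 nM in this assay, at which 1 of the 3 values shown sits, is the line that records this limit. Compound 2 and compound 3 differ in more than one place, so their values can only be set side by side without a measured step between them. The step followed here leads from compound 2 to compound 4, `CC(C)(C)c1ccc(/C=C/C(=O)c2ccc(OCC(=O)N[C@H]3CCOC3=O)cc2)cc1`, and consists of 4-(tert-butyl)phenyl in place of 2-chlorophenyl on a double-bonded chain carbon bound to a double-bonded chain carbon. Among the measured compounds shown here, no measured pair in this set isolates a swap of this kind, so there is no directly comparable step to lean on, and the expected change is modest and uncertain in direction. For compound 4 a shift in this assay of a 1.2-fold higher number from compound 2 to compound 4 (0.09 log units; within the scatter) is expected. The value of compound 4 in this assay is estimated at 4000 nM, within a range from 1000 nM to 16000 nM.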

Compound 4, half-maximal inhibitory concentration: 6570 nM
The estimate for compound 4 lay 1.6-fold (0.22 log units) below the measured number; the range from low to high includes it.
By their numbers in this assay, from the lowest: compound 2; then compound 4; then compound 3. At a limit, above all of these: compound 1.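

In this assay, putting 4-(tert-butyl)phenyl in place of 2-chlorophenyl on a double-bonded chain carbon bound to a double-bonded chain carbon produces a 2.0-fold higher number from compound 2 to compound 4 (0.31 log units; beyond the scatter) and gives this set its first measured change in one place. The earlier compounds shown here differ in more than one place and could only be set side by side, whereas this step isolates a single group. It shows that the entering group, with more heavy atoms than the one it replaces, costs only a modest step at this position and leaves a plain number well clear of the assay limit. Nothing measured here bears on why the number moves as it does.

This single step changes the substituent and its numbered place on the ring together, so it cannot show which of the two accounts for the shift. Also open, as far as these compounds go, is whether a plain phenyl, or a phenyl carrying an amine or a carboxylic acid, would give a number closer to that of compound 2 or further from it.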